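The source may hold more compounds than are shown below. What is called first, only, known or untested is meant among the compounds shown, and "the series" means these compounds.

Compound 1 `COc1cc(C)cc(-c2c(-c3ccnc(-c4ccc(C(C)=O)cc4)c3)cnn2CC#N)c1` is one of two compounds examined in a functional assay on SF-268 cells (Homo sapiens) for inhibition, read by sulforhodamine B assay, with a stated time of 48 h (on this read-out higher numbers stand for weaker inhibition of growth and lower numbers for stronger inhibition of growth), where compound 1 gives 3140 nM. Its companion, compound 2 `Cc1cc(O)cc(-c2nn(CC#N)cc2-c2ccnc(-c3ccc(N(C)C)cc3)c2)c1`, gives 3550 nM in this assay, and the two numbers sit so close together that they fall within the scatter of repeated measurements; the account therefore treats them as indistinguishable rather than as ordered.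

The next compound, compound 3 `COc1cc(C)cc(-c2c(-c3ccnc(-c4ccc(N(C)C)cc4)c3)cnn2CC#N)c1`, has not yet been measured. It differs from compound 1 in a single place: dimethylamino in place of acetyl on an aromatic carbon. Compound 2 already carries the dimethylamino group on the same outer ring, though with a different substituent on the other aryl group of the shared core, and its value in this assay stands no further from compound 1 than the scatter allows. On that basis the step from compound 1 to compound 3 is expected to be small, with no direction beyond the scatter, and the estimated change is a 1.1-fold higher number from compound 1 to compound 3 (0.05 log units; within the scatter). Compound 3 is therefore expected to give about 3500 nM in this assay, within a range from 1500 nM to 8000 nM.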

Compound 3, concentration for 50% growth inhibition: 302 nM
Compound 3: the middle estimate sits 12-fold (1.06 log units) above what was measured; the measured number lies below the stated range.
By their numbers in this assay, from the lowest: compound 3; then compounds 1 and 2 (each within the scatter of the next).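

In this assay, the group on the outer ring proves to be far from a silent feature of these compounds: dimethylamino in place of acetyl on an aromatic carbon, para to a large group, brings a 10-fold lower number from compound 1 to compound 3 (1.02 log units; beyond the scatter). The two groups match in their number of heavy atoms and in their hydrogen-bond donors and acceptors, so those counts do not separate them, and the difference in atoms is oxygen in acetyl against nitrogen in dimethylamino. Nothing shown here gives a measured property that would account for the size of this step.

Whether the lower number depends on dimethylamino itself stays open, since other groups at this position, such as a primary amine, a cyclic amine like morpholine, or a methoxy group, do not appear among the compounds shown. On these data alone, it also remains open how far this single step carries to other versions of the shared core, including that of compound 2, which already bears the 4-(dimethylamino)phenyl group but differs from compound 3 in more than one place.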